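Swapping the five-membered heteroaryl on the amide carbonyl

A few compounds are considered here, and "the series" means these few. Any claim that something is new, unique, unknown or untested is made for them only; others in the source may bear on it.

Measured so far:
- compound 1, `COc1cc2c(Oc3ccc(NC(=O)c4cc(-c5ccc(F)cc5)on4)cc3)ccnc2cc1OCCCN1CCC(C)CC1`, 3340 nM
- compound 2, `COc1cc2c(Oc3ccc(NC(=O)c4nc(-c5ccc(F)cc5)no4)cc3)ccnc2cc1OCCCN1CCC(C)CC1`, 870 nM
- compound 3, `COc1cc2c(Oc3ccc(NC(=O)C4(c5nnc(-c6ccc(F)cc6)o5)CC4)cc3F)ccnc2cc1OCCCN1CCN(C)CC1`, 143 nM

In a functional assay on A549 cells (Homo sapiens) for antiproliferative activity, read by MTT assay, with a stated time of 72 h (a higher number here means a weaker inhibitor, a lower number a stronger inhibitor), compound 2 holds the second highest of the three numbers. Its nearest neighbour is compound 1, which gives 3340 nM. For the measured compounds named here, compound 3 differs from compound 2 in several places at once, and no single step is counted between them; compound 3 gives 143 nM.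

Compound 4, `COc1cc2c(Oc3ccc(NC(=O)c4ncc(-c5ccc(F)cc5)o4)cc3)ccnc2cc1OCCCN1CCC(C)CC1`, has not yet been measured. It differs from compound 2 in one place: 5-(4-fluorophenyl)-1,3-oxazol-2-yl in place of 3-(4-fluorophenyl)-1,2,4-oxadiazol-5-yl on a carbonyl carbon.

Going by the values given here, only one measured step touches the same position. Going a 3.8-fold lower number from compound 1 to compound 2 (0.58 log units; beyond the scatter), the change of the heteroaryl on the carbonyl carbon moved the number beyond the scatter, so this position is sensitive. That step, however, concerns a different pair of rings, and nothing measured shows what the 5-(4-fluorophenyl)-1,3-oxazol-2-yl does in place of the 3-(4-fluorophenyl)-1,2,4-oxadiazol-5-yl. Compound 4 is therefore expected to stay close to compound 2, with a step of a 1.4-fold higher number from compound 2 to compound 4 (0.14 log units; within the scatter) that may well fall within the scatter. For compound 4 in this assay the estimate is 1200 nM, with a range from 400 nM to 3600 nM.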

Compound 4, half-maximal inhibitory concentration: 240 nM
Compound 4: the middle estimate sits 5.0-fold (0.70 log units) above what was measured; measured number outside the range, below it.
By their numbers in this assay, from the lowest: compounds 3 and 4 (each within the scatter of the next); then compound 2; then compound 1.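

In this assay, the 5-(4-fluorophenyl)-1,3-oxazol-2-yl on the carbonyl carbon gives a second step beyond the scatter at this position (a 3.6-fold lower number from compound 2 to compound 4 (0.56 log units; beyond the scatter)), so the earlier step was not an isolated effect of one ring pair. The clearest new information comes from the wider comparison (a 14-fold lower number from compound 1 to compound 4 (1.14 log units; beyond the scatter)): the 5-(4-fluorophenyl)-1,2-oxazol-3-yl and the 5-(4-fluorophenyl)-1,3-oxazol-2-yl differ only in how the atoms of the five-membered ring are arranged and where it joins the carbonyl carbon, yet this alone produces a large step, and across compound 1, compound 2 and compound 4, which share the rest of the structure, the ring type sets the number. No measured evidence explains why these rings rank as they do.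

The compounds shown do not separate the contribution of the ring atoms from that of the point of attachment on the five-membered ring. Going by these compounds, it also remains open whether a 5-(4-fluorophenyl)-1,3-thiazol-2-yl would keep the number of compound 4 (240 nM), and whether the oxazole would tolerate a plain phenyl or a 4-chlorophenyl in place of the 4-fluorophenyl.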